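A bromine-for-chlorine twin of compound 3 in the cell assay

The compounds below may be only part of what the source reports. "The series", "measured", "known", "first", "only" and "open" are said of these compounds alone.

Measured so far:
- compound 1, `CCOC(=O)C1=C(N/C=N/c2ccccn2)Nc2[nH]nc(C)c2C1c1ccc(N(C)C)cc1`: 29200 nM
- compound 2, `CCOC(=O)C1=C(N)Nc2[nH]nc(C)c2C1c1ccc(N(C)C)cc1`: 6220 nM
- compound 3, `CCOC(=O)C1=C(N/N=C(/C(=O)Br)c2ccc(Cl)cc2)Nc2[nH]nc(C)c2C1c1ccc(N(C)C)cc1`: 49300 nM

In a functional assay on HeLa cells (Homo sapiens) for inhibition, read by MTT assay, with a stated time of 48 h (a higher number here means a weaker inhibitor, a lower number a stronger inhibitor), compound 1 stands second highest of the three numbers. Its nearest neighbour is compound 3, reached by a 1.7-fold higher number from compound 1 to compound 3 (0.23 log units; within the scatter), while compound 2 lies furthest away, through a 4.7-fold lower number from compound 1 to compound 2 (0.67 log units; beyond the scatter). Among the measured compounds shown here, the only step that leaves the shared core untouched on the amine nitrogen and swaps the attached group, then, is the one to compound 3, and it stays within the scatter.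

Compound 4, `CCOC(=O)C1=C(N/N=C(/C(=O)Br)c2ccc(Br)cc2)Nc2[nH]nc(C)c2C1c1ccc(N(C)C)cc1`, has not yet been measured in this assay. It differs from compound 1 in this way: a group of 12 heavy atoms (8 carbon, 1 nitrogen, 1 oxygen, 2 bromine; one six-membered aromatic ring of carbon only) in place of a group of 8 heavy atoms (6 carbon, 2 nitrogen; one six-membered aromatic ring with 1 hetero atom), on an amine nitrogen. For the measured compounds named here, the entering group matches the one carried by compound 3 except that bromine replaces chlorine on the six-membered aromatic ring of carbon only. The step from compound 1 to compound 3 is therefore the one that bears on it, and it was small. Compound 2, with a hydrogen atom in that place, points the other way but is not the analogue here.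

Compound 4 is expected to land close to compound 3, with an estimated step of a 1.5-fold higher number from compound 1 to compound 4 (0.19 log units; within the scatter). The estimated value of compound 4 in this assay is 45000 nM, within a range of 20000 nM to 100000 nM.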

Compound 4, half-maximal inhibitory concentration: 68500 nM
For compound 4 the middle estimate is 1.5-fold (0.18 log units) below the measured one; the measured number falls inside the stated range.
By their numbers in this assay, from the lowest: compound 2; then compounds 1, 3 and 4 (each within the scatter of the next, the first and the last beyond it).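

In this assay, the exchange of chloro for bromo on an aromatic carbon comes to a 1.4-fold higher number from compound 3 to compound 4 (0.14 log units; within the scatter), so this halogen does not separate the two compounds. Among the compounds shown here, on the amine nitrogen, the group of 12 heavy atoms had stayed within the scatter of the group with a six-membered aromatic ring with 1 hetero atom when it carried chloro, whereas the bromo form gives a 2.3-fold higher number from compound 1 to compound 4 (0.37 log units; beyond the scatter), the first step between two such groups at this position to pass the scatter, though it remains modest. Set against the hydrogen atom of compound 2, the same group gives an 11-fold higher number from compound 2 to compound 4 (1.04 log units; beyond the scatter), the first large step in the series, and all three groups shown on this amine nitrogen carry higher numbers than that hydrogen atom.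

The compounds shown leave open whether a small acetyl or methyl group on this amine nitrogen would stay close to compound 2, and whether fluoro or methoxy in place of the halogen would move the number at all. No measurement is at hand that accounts for any of these differences.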